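A few compounds are considered here, and "the series" means these few. Any claim that something is new, unique, unknown or untested is made for them only; others in the source may bear on it.

- Compound 1 `CN1CCC(C(=O)N2Cc3c(NC(=O)c4ccc5ccccc5c4)n[nH]c3C2(C)C)CC1`: 270 nM
- Compound 2 `CN(C)CC(=O)Nc1n[nH]c2c1CN(C(=O)C(C)(C)C)C2(C)C`: 580 nM
- Compound 3 `CN1CCC(C(=O)Nc2n[nH]c3c2CN(C(=O)C(C)(C)C)C3(C)C)CC1`: 350 nM

These values come from a functional assay on A2780 cells (Homo sapiens) for antiproliferative activity, read by fluorescence, with a stated time of 72 h; on this read-out lower numbers stand for stronger inhibition and higher numbers for weaker inhibition. Compound 1 and compound 3 lie within the usual scatter of each other, so neither can be ranked ahead of the other. Compound 2 has a higher number than compound 1, by a margin beyond the scatter.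

The unmeasured compound 4 `CN1CCC(C(=O)N2Cc3c(NC(=O)c4ccc(C(F)(F)F)cc4)n[nH]c3C2(C)C)CC1` differs from compound 1 in one place, on a carbonyl carbon whose other neighbour is an amide-type nitrogen: 4-(trifluoromethyl)phenyl in place of naphthalen-2-yl on a carbonyl carbon. In short, 4-(trifluoromethyl)phenyl stands in place of naphthalen-2-yl.

Going by the values given here, no measured step covers this swap. The only one available is a 1.7-fold lower number from compound 2 to compound 3 (0.22 log units; within the scatter), and it concerns a different group, so it offers only indirect guidance. Compound 3 carries no naphthalen-2-yl group, and its 350 nM still lies within the scatter of compound 1. This gives no sign that the swap must bring a large change, although the data cannot rule one out.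

In this assay, the expected result is therefore no change beyond the scatter, with an estimated 1.3-fold higher number from compound 1 to compound 4 (0.11 log units; within the scatter). For compound 4 the estimated value is 350 nM, with an expected range of 140 nM to 900 nM.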

Compound 4, half-maximal inhibitory concentration: 60 nM
Compound 4: the middle estimate sits 5.8-fold (0.77 log units) above what was measured; the whole stated range lies above it.
By their numbers in this assay, from the lowest: compound 4; then compounds 1, 3 and 2 (each within the scatter of the next, the first and the last beyond it).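

In this assay, the group on the carbonyl carbon whose other neighbour is an amide-type nitrogen clearly matters: 4-(trifluoromethyl)phenyl in place of naphthalen-2-yl gives a 4.5-fold lower number from compound 1 to compound 4 (0.65 log units; beyond the scatter) in this comparison. Going by these compounds alone, the earlier compounds could not show this, as their only step concerned a different group and stayed within the scatter, whereas this step goes beyond it. It also shows that, in this series, a second aromatic ring at this position is not required for a low number, since the entering group has one six-membered aromatic ring of carbon only where the leaving group has two, at an equal heavy-atom count, and no measurement available here accounts for the size of the step.

The swap changes two things at once, removing the second ring and bringing in the trifluoromethyl group, so the compounds shown cannot separate the share of each. A phenyl ring with no substituent, or one carrying a nitrile or an amine in place of trifluoromethyl, would be needed to tell whether the trifluoromethyl group itself contributes or a single ring is enough.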